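Trimming a Methyl from the Aryl Sulfone

This account rests on a few compounds, and the source may have more. Where it says the series, first, only, none or still open, it means among the compounds named here.

Of the compounds shown here, two have been measured in an assay on isolated protein for displacement of a labelled ligand from metabotropic glutamate receptor 5 (Homo sapiens), with a stated time of 60 min, tested at 1 uM; a lower number here means less inhibition, a higher number more inhibition at the concentration tested (going by the name of the read-out). Compound 1 `Cc1ccc(S(=O)(=O)c2cnc3ccc(F)cc3c2N2CCC(C)CC2)cc1F` gives 86%. Within the data shown here, compound 2 `COc1ccc2ncc(S(=O)(=O)c3ccc(C)c(F)c3)c(N3CCC(C)CC3)c2c1` gives 73%, the lower of the two numbers, the only change between them being a number 13 percentage points lower from compound 1 to compound 2 (beyond the scatter).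

Compound 3 `COc1ccc2ncc(S(=O)(=O)c3cccc(F)c3)c(N3CCC(C)CC3)c2c1` is the next compound. It differs from compound 2 by hydrogen in place of methyl on an aromatic carbon, so the aryl sulfone goes from 3-fluoro-4-methylphenyl to 3-fluorophenyl.

Among the measured compounds shown here, no measured step bears on this change: the one step measured so far alters the shared core, not the aryl sulfone, so there is nothing to set the size or direction from. Removing a single carbon is a small change, and the expectation is a step at most just beyond the scatter, more likely downward. Compound 3 is therefore estimated at 65%, with a range from 45% to 85%. The estimated step is a number 8 percentage points lower from compound 2 to compound 3 (within the scatter).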

Compound 3, a percentage reported as inhibition, at one concentration (the size of the read-out at that concentration, not a potency): 68%
The estimate for compound 3 lay 3 percentage points below the measured number; the measured number falls inside the stated range.
By their numbers in this assay, from the lowest: compounds 3 and 2 (each within the scatter of the next); then compound 1.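

Among these compounds, this is the first change to the aryl sulfone rather than the shared core. In this assay, going from 3-fluoro-4-methylphenyl to 3-fluorophenyl gives a number 5 percentage points lower from compound 2 to compound 3 (within the scatter), so on this core the methyl can be replaced by hydrogen without a change that stands clear of the scatter at the concentration tested. No supporting data are available to explain this result.

Because the read-out comes from one concentration, it leaves open whether potency stays the same after this change, and whether the same swap would behave alike on the fluoro-substituted core of compound 1. It also leaves open how this ring position would respond to a larger or differently charged group, such as an ethyl group, an amine or a carboxylic acid.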